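Replacing a Cyclic Amide with an Anilide

The compounds below may be only part of what the source reports. "The series", "measured", "known", "first", "only" and "open" are said of these compounds alone.

Three compounds have been measured in an assay on isolated protein for inhibition of cathepsin S (Homo sapiens), read by fluorescence, with a stated time of 20 min; a lower number here means a stronger inhibitor, a higher number a weaker inhibitor:

Compound 1 `N#CC1(NC(=O)[C@@H]2C[C@@H](S(=O)(=O)c3ccccc3)C[C@H]2C(=O)N2CCOCC2)CC1` gives 0.7 nM.
Compound 2 `CN1CCN(C(=O)[C@@H]2C[C@H](S(=O)(=O)c3ccccc3)C[C@H]2C(=O)NC2(C#N)CC2)CC1` gives 2 nM.
Compound 3 `N#CC1(NC(=O)[C@@H]2C[C@@H](S(=O)(=O)c3ccccc3)C[C@H]2C(=O)N2CCC(O)CC2)CC1` gives 1 nM.

Compound 3 sits in the middle of these three numbers: one neighbouring step is a 1.4-fold higher number from compound 1 to compound 3 (0.15 log units; within the scatter), and the other is a 2.0-fold lower number from compound 2 to compound 3 (0.30 log units; within the scatter), so on this assay compound 3 is not separated from either of the other two.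

Compound 4 `N#CC1(NC(=O)[C@@H]2C[C@@H](S(=O)(=O)c3ccccc3)C[C@H]2C(=O)Nc2ccc(F)cc2)CC1` differs from compound 3 in one place: (4-fluorophenyl)amino in place of 4-hydroxypiperidin-1-yl on a carbonyl carbon. All three measured steps change the group on this same carbonyl carbon, but each swaps one saturated ring amine for another; the largest of them is a 2.9-fold higher number from compound 1 to compound 2 (0.46 log units; beyond the scatter), while the other two lie inside the scatter. Going by the values given here, none of them replaces a ring amine with an aromatic amine carrying a hydrogen, so no measured step speaks directly to this change. The measured steps show that this position tolerates variation with small effect, so a step of a 2.0-fold higher number from compound 3 to compound 4 (0.30 log units; within the scatter) in this assay is expected, at most modestly weakening. Compound 4 is therefore estimated at 2 nM, with a range from 0.5 nM to 8 nM.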

Compound 4, half-maximal inhibitory concentration: 26 nM
The estimate for compound 4 lay 13-fold (1.11 log units) below the measured number, outside the stated range (above it).
By their numbers in this assay, from the lowest: compounds 1, 3 and 2 (each within the scatter of the next, the first and the last beyond it); then compound 4.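

In this assay the group on this carbonyl carbon proves to matter far more than the ring amines alone suggested: (4-fluorophenyl)amino makes the inhibitor much weaker than 4-hydroxypiperidin-1-yl (a 26-fold higher number from compound 3 to compound 4 (1.41 log units; beyond the scatter)). The same large change appears when it replaces 4-methylpiperazin-1-yl (a 13-fold higher number from compound 2 to compound 4 (1.11 log units; beyond the scatter)) or morpholin-4-yl (a 37-fold higher number from compound 1 to compound 4 (1.57 log units; beyond the scatter)), so among these three compounds the result does not depend on which ring amine leaves, and each of these steps exceeds the largest step among the ring amines (a 2.9-fold higher number from compound 1 to compound 2 (0.46 log units; beyond the scatter)). Nothing shown here explains why this swap weakens inhibition so much.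

Compound 4 changes several things at once, since a saturated ring on a ring nitrogen gives way to an aromatic ring on an amide nitrogen that carries a hydrogen, and it also brings in fluorine, so the compounds shown cannot say which of these features goes with the weaker number. A cyclohexylamino group would keep the hydrogen on that nitrogen with a saturated ring, and an unsubstituted phenylamino group would drop only the fluorine, so these two would begin to separate those features.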